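The compounds below may be only part of what the source reports. "The series", "measured", "known", "first", "only" and "open" are said of these compounds alone.

Measured so far in a toxicity assay on HT-29 cells (Homo sapiens) for cytotoxicity; a lower number here means that less compound is tolerated, a higher number that more compound is tolerated:
compound 1 `CN1C(=S)[C@@H](NC(=O)c2nc(Cc3ccccc3)n(C)n2)COc2ccccc21`, > 100000 nM, a limit of the assay
compound 2 `CCn1nc(C(=O)N[C@H]2COc3ccccc3N(C)C2=S)nc1Cc1ccccc1`, > 100000 nM, a limit of the assay
compound 3 `CN1C(=S)[C@@H](NC(=O)c2nc(Cc3ccccc3)n(CCCO)n2)COc2ccccc21`, > 100000 nM, a limit of the assay

Compound 3 stands only at a limit in this assay. The two further values shown are limits as well, so compound 3 cannot be ranked against them. The steps a step that the two limits leave unreadable from compound 1 to compound 2, a step that the two limits leave unreadable from compound 1 to compound 3 and a step that the two limits leave unreadable from compound 2 to compound 3 are all unreadable because of the limit of > 100000 nM in this assay, at which 3 of the 3 values shown sit.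

Compound 4 `CN1C(=S)[C@@H](NC(=O)c2nc(Cc3ccccc3)n(C3CCCCCC3)n2)COc2ccccc21` differs from compound 3 by cycloheptyl in place of 3-hydroxypropyl on an aromatic nitrogen. Among the measured compounds shown here, no measured step exchanges the substituent on that aromatic nitrogen for a ring, so no read step bears on the change directly; the three measured variations on that nitrogen all sit at the same limit, and none shows a step of readable size in either direction. Nothing in the numbers points to compound 4 leaving the limit, and no step beyond the scatter is expected in this assay.

Compound 4 is therefore estimated at 100000 nM, with a range of 30000 nM to 300000 nM, most likely reported again only as a limit. The expected step is a number no higher from compound 3 to compound 4 (the limit leaves the size open).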

Compound 4, half-maximal cytotoxic concentration: > 100000 nM
Compound 4 ended at the assay's limit (the forecaster's own chance of this, stated with the estimate: 75%); the middle value lies on the limit itself.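

In this assay compound 4 gives > 100000 nM, a limit of the assay. No step from compound 1, compound 2 or compound 3 to compound 4 can be read: the limit of > 100000 nM in this assay, at which 4 of the 4 values shown sit.

The compounds shown leave open whether the group on the aromatic nitrogen changes the read-out in this assay at all.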